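Pyrazolo-fused series: phenyl for ethyl on the aromatic nitrogen

The source may hold more compounds than are shown below. What is called first, only, known or untested is meant among the compounds shown, and "the series" means these compounds.

Measured so far in a functional assay on the whole organism with Rattus norvegicus as the target; a higher number here means that more compound is needed for the effect, a lower number that less compound is needed:
compound 1 `Cn1nc(Cl)c2c1NC(=O)CN=C2c1ccccc1`: 63 mg/kg
compound 2 `CCn1nc(C)c2c1NC(=O)CN=C2c1ccccc1Cl`: 8 mg/kg
compound 3 `C=CCN1C(=O)CN=C(c2ccccc2Cl)c2c(C)nn(CC)c21`: 63 mg/kg

Compound 2 has the lowest number of the three; compound 1 and compound 3 both sit well above it, as a 7.9-fold higher number from compound 2 to compound 3 (0.90 log units; beyond the scatter) shows for the latter. Compound 4 `Cc1nn(-c2ccccc2)c2c1C(c1ccccc1Cl)=NCC(=O)N2` differs from compound 2 by phenyl in place of ethyl on an aromatic nitrogen. Going by the values given here, no measured step touches this position: the one step recorded, from compound 2 to compound 3, concerns the amide-type nitrogen, and compound 1 differs from compound 2 in more than one place. The change is therefore unanchored, and a step no larger than the scatter is expected, with wide uncertainty. Compound 4 is estimated at 16 mg/kg (range 4 mg/kg to 63 mg/kg), i.e. an expected 2.0-fold higher number from compound 2 to compound 4 (0.30 log units; within the scatter).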

Compound 4, minimum effective dose: 500 mg/kg
Estimate against measurement, compound 4: 31-fold (1.49 log units) below, and the stated range ends below it.
By their numbers in this assay, from the lowest: compound 2; then compounds 1 and 3 (each within the scatter of the next); then compound 4.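

The aromatic nitrogen is a sensitive position in this assay: phenyl in place of ethyl gives a 63-fold higher number from compound 2 to compound 4 (1.80 log units; beyond the scatter). This step is larger than the one at the amide-type nitrogen, where allyl in place of hydrogen gives a 7.9-fold higher number from compound 2 to compound 3 (0.90 log units; beyond the scatter). No evidence at hand accounts for the step at the aromatic nitrogen.

As far as these compounds go, only ethyl and phenyl can be compared directly at this position, so the shape of the trend remains open. A propyl chain or a benzyl group here would test whether the step follows the aromatic ring or the larger group alone.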